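Flipping two chain stereocentres in a dimethylamino ester

The source may hold more compounds than are shown below. What is called first, only, known or untested is meant among the compounds shown, and "the series" means these compounds.

Measured in a functional assay on cells (Platelet, Oryctolagus cuniculus) for inhibition, read by turbidimetry, with a stated time of 5 min; on this read-out higher numbers stand for weaker inhibition and lower numbers for stronger inhibition:
- Compound 1 `CCCC[C@@H]1NC(=O)c2ccccc21`: 700000 nM
- Compound 2 `CCCC[C@H](OC(C)=O)c1ccccc1C(=O)O[C@H]1CO[C@H]2[C@@H]1OC[C@H]2OC(=O)c1ccccc1[C@H](CCCC)OC(C)=O`: 330000 nM
- Compound 3 `CCCC[C@@H](OC(=O)CN(C)C)c1ccccc1C(=O)O[C@H]1CO[C@H]2[C@@H]1OC[C@H]2OC(=O)c1ccccc1[C@@H](CCCC)OC(=O)CN(C)C`: 680000 nM

Compound 3, at 680000 nM, sits level with compound 1 within the scatter of repeated measurements. Compound 2 has a lower number than compound 3, a gap just beyond that scatter.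

Compound 4 `CCCC[C@H](OC(=O)CN(C)C)c1ccccc1C(=O)O[C@H]1CO[C@H]2[C@@H]1OC[C@H]2OC(=O)c1ccccc1[C@H](CCCC)OC(=O)CN(C)C` has the same atoms and bonds as compound 3 and differs only in configuration as drawn (the two compounds have the same atoms and bonds and differ only in configuration as drawn: 2 of 6 stereo elements differ; a stereocentre at a saturated chain carbon is drawn R in compound 3 and S in compound 4; a stereocentre at a saturated chain carbon is drawn R in compound 3 and S in compound 4). Each changed stereocentre, at a saturated chain carbon, is drawn R in compound 3 and S in compound 4. In other words, the groups on those carbons are arranged differently in space, while the connectivity stays the same.

Going by the values given here, no measured pair here isolates such a change, so the data offer only an indirect guide. Compound 4 is drawn with the same arrangement at these chain carbons as compound 2, which carries a different ester and gives 330000 nM. This points modestly towards a lower number in this assay. The expected change a 1.4-fold lower number from compound 3 to compound 4 (0.13 log units; within the scatter) is small, close to the scatter. Compound 4 is estimated at 500000 nM, with an expected range of 220000 nM to 1100000 nM.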

Compound 4, half-maximal inhibitory concentration: 310000 nM
For compound 4 the middle estimate is 1.6-fold (0.21 log units) above the measured one; measured number inside the range.
By their numbers in this assay, from the lowest: compounds 4 and 2 (each within the scatter of the next); then compounds 3 and 1 (each within the scatter of the next).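

Going by these compounds alone, until this result, no pair of compounds isolated the arrangement at these two saturated chain carbons. The pair now shows a 2.2-fold lower number from compound 3 to compound 4 (0.34 log units; beyond the scatter) in this assay and places the change just past the noise, so the step is modest but readable, and it runs towards stronger inhibition when both carbons are drawn S rather than R. With the dimethylamino ester held constant and no group entering or leaving, the shift can be attributed to the spatial arrangement alone, because of one structural fact: the fact that compounds 3 and 4 differ only in the configuration as drawn

As far as these compounds go, both stereocentres change together, so it remains open whether one chain carbon carries the shift or the two share it, a question that would take a compound drawn R at one carbon and S at the other to settle. From the compounds shown here alone, it is also open whether the same step would appear with a free hydroxyl in place of the ester on these carbons, or with a longer chain in place of the present one.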